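Trading Trifluoromethyl for Iodo on the Aromatic Ring

The source may report more compounds than this note shows. Statements on the series, on what has been measured and on what is new or still open speak of the compounds shown alone.

Compound 3 `O=C1C(Nc2ccc(C(F)(F)F)cc2)=CC(=O)c2c1nc1n2[C@H]2OC[C@@H](O)[C@H]2OC1` is measured in a functional assay on ECa-109 cells for inhibition, with ECa-109 cell line (Homo sapiens) as the target, read by sulforhodamine B assay (a higher number here means a weaker inhibitor, a lower number a stronger inhibitor), where it gives 2250 nM. For the measured compounds named here, the only other full number belongs to compound 2 `O=C1C(Nc2ccccc2)=CC(=O)c2c1nc1n2[C@H]2OC[C@@H](O)[C@H]2OC1`, which gives 3560 nM, and the step of a 1.6-fold lower number from compound 2 to compound 3 (0.20 log units; within the scatter) stays within the scatter. Compound 1 `CCOc1ccc(NC2=CC(=O)c3c(nc4n3[C@H]3OC[C@@H](O)[C@H]3OC4)C2=O)cc1` reaches only the limit of > 4000 nM in this assay. Compound 4 `O=C1C(Nc2ccc(I)cc2)=CC(=O)c2c1nc1n2[C@H]2OC[C@@H](O)[C@H]2OC1` carries a single change from compound 3: iodo in place of trifluoromethyl on an aromatic carbon. The measured steps that touch this aromatic carbon, an at least 1.7-fold lower number from compound 1 to compound 3 (0.24 log units; that floor lies within the scatter) and a 1.6-fold lower number from compound 2 to compound 3 (0.20 log units; within the scatter), are both small, so swapping one group there for another has given no clear direction. The expected step of a 1.0-fold lower number from compound 3 to compound 4 (0.01 log units; within the scatter) is accordingly none beyond the scatter. Compound 4 is estimated at 2200 nM, within a range of 800 nM to 6000 nM.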

Compound 4, half-maximal inhibitory concentration: 2530 nM
The estimate for compound 4 lay 1.2-fold (0.06 log units) below the measured number; measured number inside the range.
By their numbers in this assay, from the lowest: compounds 3, 4 and 2 (each within the scatter of the next). At a limit, above all of these: compound 1.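

Iodo joins hydrogen and trifluoromethyl as a third group on this aromatic carbon that this assay cannot separate: the steps are a 1.1-fold higher number from compound 3 to compound 4 (0.05 log units; within the scatter) and a 1.4-fold lower number from compound 2 to compound 4 (0.15 log units; within the scatter). A single iodine atom and the four heavy atoms of trifluoromethyl thus give values within the scatter of each other, so size in heavy atoms shows no trend across these three compounds. Compound 1 stands at a limit rather than a number, leaving an at least 1.5-fold lower number from compound 1 to compound 4 (0.19 log units; that floor lies within the scatter) as only a floor: the limit of > 4000 nM in this assay, at which 1 of the 4 values shown sits.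

On these data alone, whether an amine or a carboxylic acid on this carbon would move the number beyond the scatter remains open. So does the effect of a change elsewhere on the shared core.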